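A few compounds are considered here, and "the series" means these few. Any claim that something is new, unique, unknown or untested is made for them only; others in the source may bear on it.

Measured so far:
- compound 1 `Cc1cc(Nc2cc(-c3ccccc3)[nH]n2)n2nc(SCc3c(Cl)cccc3Cl)nc2n1`: 39600 nM
- compound 2 `CCCCCc1c(C)nc2nc(SCc3ccc(Cl)cc3)nn2c1Nc1cc(-c2ccccc2)[nH]n1`: > 50000 nM
- compound 3 `Cc1cc(Nc2ccn(Cc3csc4ccc(Cl)cc34)n2)n2nc(SCc3ccc(Br)cc3)nc2n1`: 31400 nM

In an ADME assay on GES1 cells (Homo sapiens) for inhibition, read by MTT assay, with a stated time of 72 h (on this read-out higher numbers stand for weaker inhibition and lower numbers for stronger inhibition), compound 3 gives 31400 nM. For the measured compounds named here, compound 1, the only other compound with a number, gives 39600 nM, which lies within the scatter of compound 3. Compound 2 gives > 50000 nM, and this is a limit of the assay, not a number.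

Compound 4 `Cc1ccc(Cn2ccc(Nc3cc(C)nc4nc(SCc5ccc(Br)cc5)nn34)n2)cc1` has not yet been measured. The structural change is 4-methylphenyl in place of 5-chloro-1-benzothiophen-3-yl on a saturated chain carbon bound to an aromatic nitrogen. The rest of the structure stays as it is in compound 3.

Going by the values given here, no pair of measured compounds differs in one place only, so the series gives no direct size for such a change in this assay. The expectation therefore rests on compound 3 at 31400 nM and on compound 1 at 39600 nM, and it is for no step beyond the scatter, in either direction. The expected change is a 1.0-fold higher number from compound 3 to compound 4 (0.01 log units; within the scatter). For compound 4 the estimated value is 32000 nM, with an expected range of 15000 nM to 50000 nM.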

Compound 4, half-maximal inhibitory concentration: > 50000 nM
Compound 4: only a limit was reported; the forecaster's own chance of this, stated with the estimate: 20%; middle value at least 1.5-fold (0.19 log units) from the limit.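

In this assay, compound 4 gives > 50000 nM, which is a limit of the assay and not a number. For the compounds shown here, on a saturated chain carbon bound to an aromatic nitrogen, 4-methylphenyl in place of 5-chloro-1-benzothiophen-3-yl gives the first single-place step, an at least 1.5-fold higher number from compound 3 to compound 4 (0.20 log units; that floor lies within the scatter), so this position now has a reading that the earlier compounds could not give, although the step's floor does not clear the scatter. The change gives no sign of stronger inhibition in this assay, and its true size remains unknown, with only a floor available: the limit of > 50000 nM in this assay, at which 2 of the 4 values shown sit.

The change removes the fused five-membered ring, its sulfur and the chlorine together and adds the methyl, so the compounds shown cannot assign the step to any one of these parts. As far as these compounds go, it also remains open whether a different group on the same saturated chain carbon, such as an aminoethyl chain or a carboxylic acid-bearing phenyl, would give a number in this assay rather than a limit.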